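A few compounds are considered here, and "the series" means these few. Any claim that something is new, unique, unknown or untested is made for them only; others in the source may bear on it.

Measured so far in a functional assay on LS174T cells (Homo sapiens) for inhibition, with a stated time of 4 days, tested at 10 uM; a lower number here means a weaker effect, a higher number a stronger effect of the compound at the concentration tested:
- compound 1 `CN1CCN(c2ccc(C#Cc3c(F)cccc3F)cc2)CC1`: 99.6%
- compound 2 `Fc1cccc(F)c1C#Cc1ccc2c(Cl)ccnc2c1`: 70.8%
- compound 3 `CN(C)c1cnc(C#Cc2c(F)cccc2F)cn1`: 91.6%

Compound 2 stands lowest of the three numbers. The nearest to it is compound 3, whose number is higher by a margin beyond the scatter; the furthest is compound 1, also beyond the scatter. Among the compounds with values here, all three share the same alkyne-linked difluorophenyl fragment and differ in the rest of the molecule, and no two of them differ in only one place, so no measured step is available within this set.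

Compound 4 `Nc1ccnc2cc(C#Cc3c(F)cccc3F)ccc12` is not yet measured in this assay. It differs from compound 2 in a single place: amino in place of chloro on an aromatic carbon. The core of compound 2 is otherwise kept. Within the data shown here, with no measured step of this kind to lean on, the size of the change is uncertain; a modest step from compound 2 to compound 4 is expected, as a number 5.2 percentage points higher from compound 2 to compound 4 (within the scatter), in the upward direction but possibly not beyond the scatter. On that basis compound 4 is estimated at 76%, with a range from 52% to 95%.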

Compound 4, a percentage reported as inhibition, at one concentration (the size of the read-out at that concentration, not a potency): 97.7%
For compound 4 the middle estimate is 21.7 percentage points below the measured one; measured number above the stated range.
By their numbers in this assay, from the lowest: compound 2; then compounds 3, 4 and 1 (each within the scatter of the next).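

In this assay, within the data shown here, the aromatic carbon opposite the ring nitrogen is sensitive to its substituent: amino in place of chloro gives a number 26.9 percentage points higher from compound 2 to compound 4 (beyond the scatter) and is the only step that can be read at one place. The earlier compounds shown here differed in more than one place, so they could not separate this position from the rest of the molecule, whereas here the core of compound 2 is kept and one heavy atom is exchanged. No data on hand account for the size of this step.

Open, on these data alone, is whether the rise is specific to amino or would also appear with hydrogen, methoxy or dimethylamino on this carbon. Also open, as far as these compounds go, is whether the stronger effect at this concentration would hold at other concentrations, since the read-out comes from a single concentration.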